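The compounds below may be only part of what the source reports. "The series", "measured", "known", "first", "only" and "open" are said of these compounds alone.

Measured so far:
compound 1 `Cc1ncc(-c2ccccc2)c(C(C)(C)C)n1` — 22%
compound 2 `Cc1nnc2c([n+]1[O-])CC(C(C)(C)C)CC2` — 48%
compound 3 `CC(C)(C)C1CCc2nnc[n+]([O-])c2C1` — 36%

All three numbers come from a functional assay on the whole organism for inhibition, with Rattus norvegicus as the target, with stated times of 1 h and 3.5 h, at a dose of 100 mg/kg by the oral route; a lower number here means less inhibition, a higher number more inhibition at the dose given (going by the name of the read-out). Compound 3 stands second highest of the three: compound 2 lies higher and compound 1 lower, both gaps beyond the scatter. Compound 4 `CC(C)(C)C1CCc2nnc(-c3ccccc3)[n+]([O-])c2C1` differs from compound 3 by phenyl in place of hydrogen on an aromatic carbon. Within the data shown here, the one measured step at the same aromatic carbon is a number 12 percentage points lower from compound 2 to compound 3 (beyond the scatter), where the methyl left and hydrogen entered; a group entering again at that carbon in compound 4 may therefore recover part of that loss. Compound 1 carries a phenyl on a different core and gives 22%, no direct guide. Compound 4 is expected to rise by a number 9 percentage points higher from compound 3 to compound 4 (within the scatter), a modest step. The estimate for compound 4 is 45%, between 30% and 60%.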

Compound 4, a percentage reported as inhibition, in the whole organism at one dose (the size of the read-out at that dose, not a potency): 15%
Estimate against measurement, compound 4: 30 percentage points above; the measured number lies below the stated range.
By their numbers in this assay, from the lowest: compounds 4 and 1 (each within the scatter of the next); then compound 3; then compound 2.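

In this assay, the aromatic carbon between two ring nitrogen atoms proves sensitive in both directions: phenyl gives a number 21 percentage points lower from compound 3 to compound 4 (beyond the scatter), and against methyl it gives a number 33 percentage points lower from compound 2 to compound 4 (beyond the scatter). Across compound 2, compound 3 and compound 4, the order at this carbon is methyl, then hydrogen, then phenyl, so a group entering here does not by itself recover the number. No measurement at hand accounts for the fall with phenyl. Open, on these data alone, is whether an ethyl or a longer chain, or an amine, at this carbon would follow methyl or phenyl.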